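Aryl Swap on a Piperazine with Flat Adenosine A3 Binding

The compounds below may be only part of what the source reports. "The series", "measured", "known", "first", "only" and "open" are said of these compounds alone.

Compound 1: `Nc1scc(CN2CCN(c3ccc(Cl)cc3F)CC2)c1C(=O)c1ccc(Cl)cc1` with 1%
Compound 2: `Nc1scc(CN2CCN(c3ccccc3C(F)(F)F)CC2)c1C(=O)c1ccc(Cl)cc1` with 0%

The two measured compounds share one core and differ only in the aryl group on the ring amine nitrogen. In an assay on CHO cells for displacement of a labelled ligand from adenosine receptor A3 (Homo sapiens), read by scintillation counting, with a stated time of 120 min, tested at 10 uM (a lower number here means less inhibition, a higher number more inhibition at the concentration tested (going by the name of the read-out)), compound 1 gives 1%, and compound 2 gives 0%. Compound 2 holds the lower of the two numbers, but the step between the two is a number 1 percentage points lower from compound 1 to compound 2 (within the scatter), so the two values cannot be told apart.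

Compound 3, `Nc1scc(CN2CCN(c3ccncc3)CC2)c1C(=O)c1ccc(Cl)cc1`, carries the change (pyridin-4-yl in place of 2-(trifluoromethyl)phenyl on an amine nitrogen in a ring). For the measured compounds named here, the only measured step that bears on this change is the aryl exchange from compound 1 to compound 2, which gave a number 1 percentage points lower from compound 1 to compound 2 (within the scatter). Since both measured compounds sit near the floor of this assay and the aryl swap between them moved nothing beyond the scatter, the expected step to compound 3 is a number 2 percentage points higher from compound 2 to compound 3 (within the scatter), with no direction beyond the scatter. Compound 3 is therefore estimated at 2%, within a range from -8% to 12%.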

Compound 3, a percentage reported as inhibition, at one concentration (the size of the read-out at that concentration, not a potency): 2%
Beside the measured number, compound 3's estimate shows no gap at the digits printed; low and high end bracket the measured number.
By their numbers in this assay, from the lowest: compounds 2, 1 and 3 (each within the scatter of the next).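

Pyridin-4-yl brings a ring nitrogen and a hydrogen-bond acceptor to the amine nitrogen in the ring, where the earlier compounds carried only carbon-ring aryl groups, yet in this assay the exchange gives a number 2 percentage points higher from compound 2 to compound 3 (within the scatter) and a number 1 percentage points higher from compound 1 to compound 3 (within the scatter). For the compounds shown here, the earlier pair showed only that two substituted phenyl groups could not be told apart at this position; the result extends this to a smaller aryl group with a hetero atom in the ring, so neither that ring nitrogen nor the fewer heavy atoms separates compound 3 from the other two. No measured evidence bears on why the numbers stay together.

The compounds shown leave open whether a non-aromatic group at this position, such as a benzyl group, a longer alkyl chain or a carboxylic acid, would separate from these three. They also leave open whether a change elsewhere on the shared core would do so.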